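The source may report more compounds than this note shows. Statements on the series, on what has been measured and on what is new or still open speak of the compounds shown alone.

Compound 1 `COc1ccc(-c2c(C)nc3c(N4CC[C@@H](NS(=O)(=O)C(C)C)C4)cc(C)nn23)cc1OC`: > 95%
Compound 2 `COc1ccc(-c2c(C)nc3c(N4CC[C@@H](NS(N)(=O)=O)C4)cc(C)nn23)cc1OC`: > 95%
Compound 3 `COc1ccc(-c2c(C)nc3c(N4CC[C@@H](SC(C)=O)C4)cc(C)nn23)cc1OC`: > 95%

These results come from an ADME assay on microsomes from liver (Homo sapiens) for metabolic stability, read by LC-MS, with NADPH named in the record, with a stated time of 60 min, tested at 1 uM, in the absence of a further agent (a lower number here means that less of the compound is left, a higher number that more of the compound is left), and each one is a limit of the assay rather than a number. Compound 3 gives > 95%, which is a limit. It therefore has no exact place in the series, and the three compounds share one reading: the limit of > 95% in this assay, at which 3 of the 3 values shown sit.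

Compound 4 `COc1ccc(-c2c(C)nc3c(N4CC[C@@H](n5cc(-c6ccccc6)nn5)C4)cc(C)nn23)cc1OC` has not yet been measured. It keeps the shared core but carries 4-phenyl-1H-1,2,3-triazol-1-yl in place of acetylsulfanyl on a saturated ring carbon.

Going by the values given here, three measured steps bear on this change: a step that the two limits leave unreadable from compound 1 to compound 3, a step that the two limits leave unreadable from compound 2 to compound 3 and a step that the two limits leave unreadable from compound 1 to compound 2. None of them offers a size to carry over. Among the compounds with values here, they show only that the three different groups on this ring carbon all leave the reading in this assay at the same limit. None of those groups contains the aromatic rings that enter in compound 4, so the measured compounds cannot rule out a fall. A small fall at most is therefore expected, and a result at the limit again is quite possible. The expected step is a number at least 5 percentage points lower from compound 3 to compound 4 (that floor lies within the scatter). For compound 4 the estimated value is 90%, expected to lie between 70% and 100%.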

Compound 4, percent of the compound remaining: "unstable" (no number reported)
Nothing numeric was reported for compound 4; the estimate stays without a comparison.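

In this assay, compound 4 is recorded only by the word "unstable", without a number, so no new step can be read from compound 3 to compound 4. The compounds shown leave open how much of compound 4 remains, and whether either ring of the 4-phenyl-1H-1,2,3-triazol-1-yl group alone would give the same result.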